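Trimethylsilyl for Hydroxymethyl on Two Related Alkynes

The source may hold more compounds than are shown below. What is called first, only, known or untested is meant among the compounds shown, and "the series" means these compounds.

Compound 1 `CC(=O)Nc1nc(-c2cccc(NS(=O)(=O)c3ccc(C#CCO)cc3)c2)cs1` and compound 3 `CC(=O)Nc1nc(-c2cccc(NS(=O)(=O)c3cccc(C#CCO)c3)c2)cs1` are built from the same atoms joined differently; how their two cores differ is not broken down here. In a functional assay on A-375 cells (Homo sapiens) for antiproliferative activity, read by trypan blue exclusion, with a stated time of 48 h, tested at 5 uM (a lower number here means a stronger effect, a higher number a weaker effect of the compound at the concentration tested), compound 1 gives 99.3%, so at the tested concentration the cells keep dividing almost undisturbed. In this assay compound 3 gives 66.2%, a stronger effect than compound 1 shows.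

Compound 2 `CC(=O)Nc1nc(-c2cccc(NS(=O)(=O)c3ccc(C#C[Si](C)(C)C)cc3)c2)cs1` carries the change (a group of 4 heavy atoms (3 carbon, 1 silicon; no ring) in place of a group of 2 heavy atoms (1 carbon, 1 oxygen; no ring), on a triple-bonded carbon). In this assay compound 2 gives 4.2%. That is a step of a number 95.1 percentage points lower from compound 1 to compound 2 (beyond the scatter), turning a compound with hardly any effect into one that nearly stops growth outright.

Compound 4 `CC(=O)Nc1nc(-c2cccc(NS(=O)(=O)c3cccc(C#C[Si](C)(C)C)c3)c2)cs1` has not been measured. It stands to compound 3 as compound 2 stands to compound 1: the difference is a group of 4 heavy atoms (3 carbon, 1 silicon; no ring) in place of a group of 2 heavy atoms (1 carbon, 1 oxygen; no ring), on a triple-bonded carbon, and the place of the change is the same in both pairs, so this is the same change. Any expectation for compound 4 rests on a single step seen once, on a core that differs in a way not broken down here. Because compound 3 already gives 66.2%, a step of the earlier size cannot be repeated in full. The expected step is a number 56.2 percentage points lower from compound 3 to compound 4 (beyond the scatter), to be set beside the earlier one. Compound 4 is expected to give about 10% in this assay, within a range from 0% to 40%.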

Compound 4, a percentage reported as activity, at one concentration (the size of the read-out at that concentration, not a potency): < 1%
Compound 4 was reported as a limit; the forecaster's own chance of this, stated with the estimate: 0%; middle value at least 9 percentage points away from the limit.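

In this assay the change from hydroxymethyl to the trimethylsilyl group on the triple-bonded carbon gives a number at least 65.2 percentage points lower from compound 3 to compound 4 (beyond the scatter), so the direction seen on the core of compound 1 also appears on the core of compound 3. Compound 4 gives < 1%, which is a limit of the assay and not a number. The change therefore lowers the number on both of these cores, but this does not show that it does so by the same amount, and two cores are too few to make a general rule: the same change on two cores in this assay, a number 95.1 percentage points lower (beyond the scatter) from compound 1 to compound 2 and a number at least 65.2 percentage points lower (beyond the scatter) from compound 3 to compound 4; the limit leaves it open whether they differ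

The compounds shown leave open how other groups would behave on the same triple-bonded carbon, such as a tert-butyl group, which has carbon where the trimethylsilyl group has silicon, or a longer chain ending in an amine. They also leave open whether the change would carry over to any core beyond these two, and since each compound has a single reading at one concentration, they give no measure of potency.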